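This account rests on a few compounds, and the source may have more. Where it says the series, first, only, none or still open, it means among the compounds named here.

Three compounds have been measured in a functional assay on MOLT-4 cells (Homo sapiens) for cytotoxicity, with a stated time of 72 h; a higher number here means a weaker inhibitor, a lower number a stronger inhibitor:

Compound 1, `O=C1/C(=C/c2ccc(F)cc2)CCC/C1=C\c1ccccc1[N+](=O)[O-]`, gives 1870 nM.
Compound 2, `O=C1/C(=C/c2ccc(F)cc2)CCC/C1=C\c1ccc([N+](=O)[O-])cc1`, gives 17100 nM.
Compound 3, `O=C1/C(=C/c2ccc(Cl)cc2)CCC/C1=C\c1ccc([N+](=O)[O-])cc1`, gives 9120 nM.

Compounds 2 and 3 share a core and differ in one place: chloro in place of fluoro on an aromatic carbon. This change gave a 1.9-fold lower number from compound 2 to compound 3 (0.27 log units; within the scatter), so the two values cannot be told apart. Compound 1 is built on a different core from compound 2; the difference between the two cores is not broken down here. Compound 1 has the lowest of the three numbers, and its gaps to compound 3 and to compound 2 both lie beyond the scatter.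

Compound 4, `O=C1/C(=C/c2ccc(Cl)cc2)CCC/C1=C\c1ccccc1[N+](=O)[O-]`, has not yet been measured in this assay. It differs from compound 1 by the same change: chloro in place of fluoro on an aromatic carbon. The expectation for compound 4 rests on what that change did between compound 2 and compound 3, namely a 1.9-fold lower number from compound 2 to compound 3 (0.27 log units; within the scatter). On that basis the step is expected to be similarly small, a 1.6-fold lower number from compound 1 to compound 4 (0.19 log units; within the scatter). Compound 4 is therefore estimated to give 1200 nM in this assay, most likely between 500 nM and 3000 nM.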

Compound 4, half-maximal inhibitory concentration: 3860 nM
For compound 4 the middle estimate is 3.2-fold (0.51 log units) below the measured one; measured number above the stated range.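

In this assay, the change to chloro gave a 2.1-fold higher number from compound 1 to compound 4 (0.31 log units; beyond the scatter), a modest step on the core of compound 1. The same change stayed within the scatter on the other core but passed beyond it here, and the two steps differ by more than repeated measurements would explain: the same change on two cores in this assay, a 1.9-fold lower number (0.27 log units; within the scatter) from compound 2 to compound 3 and a 2.1-fold higher number (0.31 log units; beyond the scatter) from compound 1 to compound 4, 3.9-fold (0.59 log units) apart, beyond the scatter of two such steps This shows that the size and direction of this change cannot simply be copied from one core to the other in this series, although it does not show why the two cores differ, and two pairs cannot reveal which result is more typical.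

The compounds shown carry only fluoro or chloro at this place, so they leave open how a bromo group, a methyl group or an amine there would behave on either core. They also leave open whether a third halogen or other group would follow the trend of either core, or would fit neither of them.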